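The source may report more compounds than this note shows. Statements on the series, on what has been measured and on what is new or still open speak of the compounds shown alone.

Compound 1, `COc1cc(-c2nnc3n2NC(c2ccco2)C(C(=O)c2cccc(Br)c2)S3)cc(OC)c1OC`: in a functional assay on A549 cells (Homo sapiens) for cytotoxicity, read by MTT assay, with a stated time of 48 h (on this read-out lower numbers stand for stronger inhibition and higher numbers for weaker inhibition), compound 1 gives 36900 nM.
Compound 2, `COc1cc(-c2nnc3n2NC(c2ccco2)C(C(=O)c2ccccc2F)S3)cc(OC)c1OC`: compound 2 gives 78700 nM.
Compound 3, `COc1cccc(C(=O)C2Sc3nnc(-c4cc(OC)c(OC)c(OC)c4)n3NC2c2ccco2)c1`: compound 3 gives > 100000 nM, which is a limit of the assay and not a number.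

Compound 3 therefore stands at the floor of what this series shows, at the limit of > 100000 nM in this assay, at which 1 of the 3 values shown sits. Both measured steps leading to it rise: an at least 2.7-fold higher number from compound 1 to compound 3 (0.43 log units; beyond the scatter) and an at least 1.2-fold higher number from compound 2 to compound 3 (0.10 log units; that floor lies within the scatter), the second only a floor that lies within the scatter. The next compound, compound 4, `COc1cc(-c2nnc3n2NC(c2ccco2)C(C(=O)c2ccc(O)cc2)S3)cc(OC)c1OC`, carries 4-hydroxyphenyl in place of 3-methoxyphenyl on a carbonyl carbon. For the measured compounds named here, no measured step involves a 4-hydroxyphenyl, so the two steps into compound 3 are the only guide, and they point to weak inhibition for the aryl groups on the carbonyl carbon so far. Compound 4 is expected to remain near that floor, and the estimate for compound 4 is 120000 nM, with a range from 40000 nM to 350000 nM. The expected step reads a step that the limit leaves unreadable from compound 3 to compound 4, likely with the assay again reporting only a limit.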

Compound 4, half-maximal inhibitory concentration: 93400 nM
Estimate against measurement, compound 4: 1.3-fold (0.11 log units) above, within the range that was stated.
By their numbers in this assay, from the lowest: compound 1; then compounds 2 and 4 (each within the scatter of the next). At a limit, above all of these: compound 3.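

The 4-hydroxyphenyl group carries a hydrogen-bond donor that 3-methoxyphenyl lacks, yet in this assay this change reads an at least 1.0-fold lower number from compound 3 to compound 4 (0.02 log units; that floor lies within the scatter). Nor does this set its compound apart from the 2-fluorophenyl one: a 1.2-fold higher number from compound 2 to compound 4 (0.07 log units; within the scatter). Against the 3-bromophenyl group the gap is wider, with a 2.5-fold higher number from compound 1 to compound 4 (0.40 log units; beyond the scatter), so at this position on the carbonyl carbon only the 3-bromophenyl group of compound 1 stands apart from the other aryl groups. The value of compound 3 is a limit and not a number: the limit of > 100000 nM in this assay, at which 1 of the 4 values shown sits.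

Going by these compounds, whether an amine or a carboxylic acid on the phenyl ring, or a longer alkyl chain in place of the aryl group, would shift the number stays open. So does whether a 4-bromophenyl group would match the 3-bromophenyl group of compound 1.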